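The compounds below may be only part of what the source reports. "The series", "measured", "known", "first", "only" and "open" are said of these compounds alone.

In a functional assay on MOLT-4 cells (Homo sapiens) (on this read-out lower numbers stand for stronger inhibition and higher numbers for weaker inhibition), compound 1 (`OC[C@H]1C[C@@H](Cn2cnc3c(Cl)ncnc32)c2ccccc21`) gives 24 ug/mL and holds the highest number of the three measured compounds. Compound 2 (`Cn1ncc2c1[C@H](Cn1cnc3c(Cl)nc(N)nc31)C[C@@H]2CO`) gives 3.2 ug/mL and compound 3 (`Cn1ncc2c1[C@H](Cn1cnc3c(Cl)ncnc31)C[C@@H]2CO[Si](c1ccccc1)(c1ccccc1)C(C)(C)C`) gives 3.2 ug/mL and each of these two lies beyond the scatter from compound 1 on the side of stronger inhibition. The two values of compound 2 and compound 3 do not separate.

The next compound to read is compound 4 (`CC(C)Nc1ncnc2c1ncn2C[C@@H]1C[C@H](CO)c2ccccc21`). It departs from compound 1 by one change (isopropylamino in place of chloro on an aromatic carbon) with isopropylamino in place of chloro on an aromatic carbon of a six-membered aromatic ring with 2 nitrogen. Among the measured compounds shown here, all three measured compounds carry the chloro, so the series offers no direct measurement of this exchange, and no step between closely matched compounds is available as a guide.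

The expectation in this assay is therefore a small step towards weaker inhibition, possibly none beyond the scatter, and the wide range reflects that lack of precedent. The expected change is a 1.5-fold higher number from compound 1 to compound 4 (0.16 log units; within the scatter) as a working estimate. For compound 4 the estimated value is 35 ug/mL with an expected range from 10 ug/mL to 100 ug/mL in this assay.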

Compound 4, half-maximal inhibitory concentration: 24 ug/mL
The estimate for compound 4 lay 1.5-fold (0.16 log units) above the measured number, and the stated range covers the measured number.
By their numbers in this assay, from the lowest: compounds 2 and 3 (each within the scatter of the next); then compounds 1 and 4 (each within the scatter of the next).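

In this assay, among the compounds shown here, the step at this position reads no change at the digits printed from compound 1 to compound 4 (within the scatter), the first direct reading of the position, since the earlier compounds all carry chloro there. On the aromatic carbon of the six-membered aromatic ring with 2 nitrogen, chloro can therefore give way to the larger isopropylamino, which brings a hydrogen-bond donor and a hydrogen-bond acceptor, with no shift beyond the scatter in the core of compound 1, so chloro is not required there for this read-out. Nothing available explains this flat result, and it remains an observation from a single pair of compounds.

The compounds shown leave open whether other groups at this position, such as a plain primary amine, a cyclopropylamino group, a longer chain such as n-butylamino, or a methoxy group, would also leave the read-out unmoved or would separate from chloro. They also leave open whether isopropylamino in place of chloro gives the same flat step on the cores of compound 2 and compound 3, so the present reading applies only to the core of compound 1.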